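Replacing fluoro with benzyloxycarbonyl on the shared core

A few compounds are considered here, and "the series" means these few. Any claim that something is new, unique, unknown or untested is made for them only; others in the source may bear on it.

Measured in a functional assay on HeLa cells (Homo sapiens) for antiproliferative activity, read by MTT assay, with a stated time of 48 h; a lower number here means a stronger inhibitor, a higher number a weaker inhibitor:
- compound 1 `Fc1ccc2[nH]c(-c3cn(-c4ccccc4)nc3-c3ccccc3)nc2c1`: 3610 nM
- compound 2 `Fc1ccc(-c2nn(-c3ccccc3)cc2-c2nc3cc(F)ccc3[nH]2)cc1`: 1570 nM

Of these two, compound 2 gives the lower number, 1570 nM. Compound 3 `O=C(OCc1ccccc1)c1ccc2[nH]c(-c3cn(-c4ccccc4)nc3-c3ccc(F)cc3)nc2c1` has not yet been measured. It differs from compound 2 by benzyloxycarbonyl in place of fluoro on an aromatic carbon, with benzyloxycarbonyl in place of fluoro on an aromatic carbon. Going by the values given here, the only measured step, a 2.3-fold lower number from compound 1 to compound 2 (0.36 log units; beyond the scatter), was modest and concerned a fluoro elsewhere in the structure, so it bears only loosely on this change and gives no firm direction. The expected change, held with little confidence, is a 1.3-fold lower number from compound 2 to compound 3 (0.12 log units; within the scatter). For compound 3 the estimated value is 1200 nM, with an expected range of 300 nM to 5000 nM.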

Compound 3, half-maximal inhibitory concentration: 23600 nM
Compound 3: middle estimate off by 20-fold (1.29 log units), on the low side; the measured number lies above the stated range.
By their numbers in this assay, from the lowest: compound 2; then compound 1; then compound 3.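

In this assay, benzyloxycarbonyl in place of fluoro on this aromatic carbon of the shared core gives a 15-fold higher number from compound 2 to compound 3 (1.18 log units; beyond the scatter) and so weakens the compound markedly. Going by these compounds alone, the only earlier step, a 2.3-fold lower number from compound 1 to compound 2 (0.36 log units; beyond the scatter), was modest and concerned a fluoro elsewhere, so this is the first sign that this position is sensitive to what it carries. No measurement available here accounts for the change. The compounds shown leave open whether the weakening belongs to the benzyl part or to the carbonyl attached to the core. A carboxylic acid or a methyl ester on this carbon would tell these apart.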